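A few compounds are considered here, and "the series" means these few. Any claim that something is new, unique, unknown or untested is made for them only; others in the source may bear on it.

Three dichloroacetamides on a shared core have been measured in a functional assay on KB 3-1 cells (Homo sapiens) for cytotoxicity, read by MTT assay, with a stated time of 68 h; a higher number here means a weaker inhibitor, a lower number a stronger inhibitor. Going by the values given here, compound 3 `O=C(Nc1cccc(-c2ccccc2)c1)C(Cl)Cl` gives 46800 nM in this assay, the only true number among the three. Compound 1 `O=C(Nc1cccc(-c2ccc(-c3ccccc3)cc2)c1)C(Cl)Cl` gives only a limit of the assay, > 50000 nM. Compound 2 `O=C(Nc1cccc(-c2ccc(C(F)(F)F)cc2)c1)C(Cl)Cl` likewise gives only a limit of the assay, > 50000 nM. The step of an at least 1.0-fold lower number from compound 1 to compound 3 (0.02 log units; that floor lies within the scatter) and the step of an at least 1.0-fold lower number from compound 2 to compound 3 (0.02 log units; that floor lies within the scatter) therefore carry only a floor, and the step that the two limits leave unreadable from compound 1 to compound 2 cannot be read at all because the limit of > 50000 nM in this assay, at which 2 of the 3 values shown sit, applies to both of its ends.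

Compound 4 `Cc1cccc(-c2cccc(NC(=O)C(Cl)Cl)c2)c1` is the next compound to be measured in this assay. Its change from compound 3 is methyl in place of hydrogen on an aromatic carbon. The steps that bear on it are an at least 1.0-fold lower number from compound 1 to compound 3 (0.02 log units; that floor lies within the scatter) and an at least 1.0-fold lower number from compound 2 to compound 3 (0.02 log units; that floor lies within the scatter), and neither of them is shown to reach beyond the scatter. Putting a methyl back onto an aromatic carbon of compound 3 is therefore expected to give compound 4 a step of the same small kind, a 1.1-fold higher number from compound 3 to compound 4 (0.03 log units; within the scatter), with no direction that stands out from the scatter. Compound 4 is expected to give about 50000 nM, within a range from 22000 nM to 110000 nM.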

Compound 4, half-maximal inhibitory concentration: > 50000 nM
Compound 4: only a limit was reported; the forecaster's own chance of this, stated with the estimate: 50%; the middle value lies on the limit itself.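

In this assay compound 4 gives > 50000 nM, which is a limit of the assay and not a number. The methyl, a single carbon placed on an aromatic carbon meta to a large group, thus yields only a floor, an at least 1.0-fold higher number from compound 3 to compound 4 (0.02 log units; that floor lies within the scatter), so this position has no readable size of effect for this change, and no direction can be drawn from it. The earlier compounds showed the same outcome for phenyl and trifluoromethyl, and the methyl now shows that even a group of one heavy atom does not add a second true number to the series, leaving compound 3 as the only compound with one: the limit of > 50000 nM in this assay, at which 3 of the 4 values shown sit.

As far as these compounds go, whether any group at this place can give a true number, and so a step that reaches beyond the scatter, remains open, for example a hydroxyl, an amine or a carboxylic acid in place of the methyl. Also open, from the compounds shown here alone, is whether a fluorine or a methoxy on this ring would leave the number within the scatter of compound 3 or carry it clearly to either side.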